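Aryl exchange on the shared core: compound 2 to compound 3

A few compounds are considered here, and "the series" means these few. Any claim that something is new, unique, unknown or untested is made for them only; others in the source may bear on it.

Among the measured compounds shown here, in a functional assay on DU-145 cells (Homo sapiens) for cytotoxicity, read by sulforhodamine B assay, with a stated time of 48 h (a lower number here means a stronger inhibitor, a higher number a weaker inhibitor), compound 1 (`C[C@H]1CC[C@@H]2[C@@H](OC(=O)[C@]23CC(c2ccccc2Br)=NO3)[C@]2(C)C(=O)C=C[C@@]12O`) gives 18000 nM and compound 2 (`C[C@H]1CC[C@@H]2[C@@H](OC(=O)[C@]23CC(c2ccc([N+](=O)[O-])cc2)=NO3)[C@]2(C)C(=O)C=C[C@@]12O`) gives 7000 nM as the lower of the two numbers so far. Compound 3 (`COc1ccc(C2=NO[C@]3(C2)C(=O)O[C@@H]2[C@H]3CC[C@H](C)[C@]3(O)C=CC(=O)[C@@]23C)cc1OC`) has not been measured. The change from compound 2 is 3,4-dimethoxyphenyl in place of 4-nitrophenyl on a carbon with a double bond to nitrogen. For the measured compounds named here, one measured step bears on this carbon: a 2.6-fold lower number from compound 1 to compound 2 (0.41 log units; beyond the scatter) with 4-nitrophenyl in place of 2-bromophenyl. Going by the values given here, it is modest, and no measured compound carries 3,4-dimethoxyphenyl. Among the compounds with values here, with compound 2 at the low end of only two values, a small rise is expected rather than a further drop. The expected move is a 1.7-fold higher number from compound 2 to compound 3 (0.23 log units; within the scatter) in this assay. Compound 3 is estimated at 12000 nM with an expected range of 5000 nM to 28000 nM for repeated measurements.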

Compound 3, half-maximal inhibitory concentration: 84000 nM
Beside the measured number, compound 3's estimate is 7.0-fold (0.85 log units) below it; the whole stated range lies below it.
By their numbers in this assay, from the lowest: compound 2; then compound 1; then compound 3.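

In this assay, among the compounds shown here, the aryl group on the carbon with a double bond to nitrogen proves far from silent: a 12-fold higher number from compound 2 to compound 3 (1.08 log units; beyond the scatter) is a large step, whereas the only earlier step at this carbon was modest. The 3,4-dimethoxyphenyl group also separates from 2-bromophenyl, with a 4.7-fold higher number from compound 1 to compound 3 (0.67 log units; beyond the scatter) and so gives the highest number of the three, with both of its steps beyond the scatter. Nothing available accounts for the size of these steps.

The compounds shown do not separate a single methoxy group from the pair, nor the place of a group on the phenyl ring from its identity. Going by these compounds, how unsubstituted phenyl, or a phenyl ring bearing an amine or a carboxylic acid, would read in this assay remains open.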